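Amide and sulfonamide caps on the shared core

The source may hold more compounds than are shown below. What is called first, only, known or untested is meant among the compounds shown, and "the series" means these compounds.

Measured so far:
compound 1 `O=S(=O)(NCCCNc1nccc(-c2c(-c3cccc(F)c3)nc3sccn23)n1)c1cccc(F)c1`: 13700 nM
compound 2 `O=C(NCCNc1nccc(-c2c(-c3cccc(F)c3)nc3sccn23)n1)c1ccc(C(F)(F)F)cc1`: 8710 nM
compound 3 `O=C(NCCCNc1nccc(-c2c(-c3cccc(F)c3)nc3sccn23)n1)c1ccc(Cl)cc1`: 13700 nM

All three numbers come from a functional assay on A-375 cells (Homo sapiens) for cytotoxicity, read by MTT assay; a higher number here means a weaker inhibitor, a lower number a stronger inhibitor. Compound 2 stands at the low end of the three, yet neither compound 1 nor compound 3 is separated from it beyond the scatter, so the three cannot be told apart.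

The next compound, compound 4 `Cc1ccc(S(=O)(=O)NCCNc2nccc(-c3c(-c4cccc(F)c4)nc4sccn34)n2)cc1`, is not yet measured in this assay. It differs from compound 2 in one place: (4-methylphenyl)sulfonyl in place of (4-(trifluoromethyl)phenyl)carbonyl on an amine nitrogen. This is the reverse kind of swap to the one already seen within the series, where the cap on the amine nitrogen changed from a sulfonyl to a carbonyl group and the result was no change at the digits printed from compound 1 to compound 3 (within the scatter). Among the measured compounds shown here, no other measured pair bears on this change; compound 1 and compound 2 also differ in their chain, and their two values sit within the scatter of each other.

On that basis the step from compound 2 to compound 4 is expected to be a 1.1-fold higher number from compound 2 to compound 4 (0.04 log units; within the scatter), a change not exceeding the scatter. Compound 4 is therefore estimated at 9500 nM in this assay, with a range from 4000 nM to 22000 nM.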

Compound 4, half-maximal inhibitory concentration: 15400 nM
Compound 4: middle estimate off by 1.6-fold (0.21 log units), on the low side; the range from low to high includes it.
By their numbers in this assay, from the lowest: compounds 2, 1, 3 and 4 (each within the scatter of the next).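

In this assay, the step on the amine nitrogen from (4-(trifluoromethyl)phenyl)carbonyl to (4-methylphenyl)sulfonyl gives a 1.8-fold higher number from compound 2 to compound 4 (0.25 log units; within the scatter), so the parity of carbonyl and sulfonyl caps seen in no change at the digits printed from compound 1 to compound 3 (within the scatter) now holds on a second chain and with a different pair of ring substituents. The two steps that alter chain and cap together, a 1.1-fold higher number from compound 3 to compound 4 (0.05 log units; within the scatter) and a 1.1-fold higher number from compound 1 to compound 4 (0.05 log units; within the scatter), also stay within the scatter, so neither the cap type, the ring substituent nor the chain separates any of the four compounds in these data. Nothing measured here speaks to what lies behind this flat reading.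

From the compounds shown here alone, all four caps carry a substituted phenyl ring on a carbonyl or sulfonyl group, so it remains open whether a cap bearing a basic amine or a carboxylic acid in place of that ring would move the number beyond the scatter. A longer chain between the amine nitrogen and the shared core is equally untested in the compounds shown, and any such change would have to be read against this narrow band of values.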